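The source may report more compounds than this note shows. Statements on the series, on what has been measured and on what is new or still open speak of the compounds shown alone.

Measured set, in an ADME assay on PC-3 cells (Homo sapiens) for cytotoxicity, read by WST assay, tested at 100 uM; a lower number here means less inhibition, a higher number more inhibition at the concentration tested (going by the name of the read-out):
compound 1 `CC(C)(C)OC(=O)c1cccc(NC(=O)C2CCCN(C(=O)c3cc(C(F)(F)F)cc(C(F)(F)F)c3)C2)c1` gives 0%
compound 2 `CSc1cccc(NC(=O)C2CCCN(C(=O)c3cc(C(F)(F)F)cc(C(F)(F)F)c3)C2)c1` gives 0%
compound 3 `O=C(Nc1cccc(S(=O)(=O)N2CCCC2)c1)C1CCCN(C(=O)c2cc(C(F)(F)F)cc(C(F)(F)F)c2)C1` gives 0%

Compound 2 stands level with compounds 1 and 3 at the digits shown. Its nearest neighbour is compound 1, with no change at the digits printed from compound 1 to compound 2 (within the scatter); its furthest is compound 3, with no change at the digits printed from compound 2 to compound 3 (within the scatter). The remaining pair behaves the same way, no change at the digits printed from compound 1 to compound 3 (within the scatter).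

The next compound, compound 4 `O=C(Nc1ccc(Cl)cc1)C1CCCN(C(=O)c2cc(C(F)(F)F)cc(C(F)(F)F)c2)C1`, has not been measured in this assay. It differs from compound 2 as follows: 4-chlorophenyl in place of 3-(methylsulfanyl)phenyl on an amide-type nitrogen.

All three measured steps swap one substituent on the aromatic ring attached to the amide-type nitrogen while the rest of the shared core is kept, and none of them moves the read-out beyond the scatter. The change to compound 4 is again confined to that aryl portion, with the amide and the rest of the core unchanged. On these three steps no movement in this assay is expected for compound 4, and the step from compound 2 is estimated as no change at the digits printed from compound 2 to compound 4 (within the scatter), in neither direction beyond the scatter.

Compound 4 is therefore estimated at 0% in this assay, with an expected range from -10% to 12%.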

Compound 4, a percentage reported as inhibition, at one concentration (the size of the read-out at that concentration, not a potency): 14%
The estimate for compound 4 lay 14 percentage points below the measured number; measured number above the stated range.
By their numbers in this assay, from the lowest: compounds 1, 2 and 3 (each within the scatter of the next); then compound 4.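

In this assay, among the compounds shown here, the aryl group on the amide-type nitrogen now gives a first step that leaves the scatter, with a number higher a number 14 percentage points higher from compound 2 to compound 4 (beyond the scatter) and the size of that step printed as modest. Compounds 1, 2 and 3 showed only that swapping one substituent on this aryl group could leave the read-out flat, whereas 4-chlorophenyl in place of 3-(methylsulfanyl)phenyl shows that this position can register a difference at the single concentration tested. No supporting data bear on why the number rises.

As far as these compounds go, the step replaces the substituent and changes its numbered place on the ring at once, so it remains open whether the rise follows the chlorine, its place in 4-chlorophenyl, or the departure of methylsulfanyl. Also open, from the compounds shown here alone, is how the series would read in this assay with an unsubstituted phenyl, with bromine in place of the chlorine, or with an amine or a carboxylic acid on this aryl group, and whether any such change would move the read-out further than this step did.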